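Dropping a (piperidin-1-yl)methyl group: an expected small step

A few compounds are considered here, and "the series" means these few. Any claim that something is new, unique, unknown or untested is made for them only; others in the source may bear on it.

Of the compounds shown here, two have so far been measured in a functional assay on THP-1 cells (Homo sapiens) for inhibition, read by ELISA, with stated times of 30 min and 24 h, tested at 1 uM; on this read-out higher numbers stand for a stronger effect at the one concentration tested and lower numbers for a weaker effect. Compound 1, `COc1cc(O)c(C(=O)c2cccc(F)c2)c(OC)c1`, gives 38% in this assay. Compound 2, `COc1cc(OC)c(C(=O)c2cccc(Cl)c2)c(O)c1CN1CCCCC1`, gives 33% in this assay, the lower of the two numbers, but the gap to compound 1 lies within the usual scatter, so no order between them can be claimed.

Compound 3, `COc1cc(O)c(C(=O)c2cccc(Cl)c2)c(OC)c1`, has not yet been measured. It differs from compound 2 in one place: hydrogen in place of (piperidin-1-yl)methyl on an aromatic carbon. Compound 3 thus resembles compound 1 in lacking the (piperidin-1-yl)methyl group, while keeping the (3-chlorophenyl)carbonyl group of compound 2.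

Among the compounds with values here, no step between the two measured compounds is known, and their values show no difference beyond the scatter. Compound 3 is expected to give about 38% in this assay, within a range from 22% to 54%, because compound 1 gives 38% without that group. The step of a number 5 percentage points higher from compound 2 to compound 3 (within the scatter) is expected to stay within the scatter, with no clear direction.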

Compound 3, a percentage reported as activity, at one concentration (the size of the read-out at that concentration, not a potency): 31%
Estimate against measurement, compound 3: 7 percentage points above; the range from low to high includes it.
By their numbers in this assay, from the lowest: compounds 3, 2 and 1 (each within the scatter of the next).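

In this assay, removing the (piperidin-1-yl)methyl group from the aromatic carbon ortho to a hydroxy group gives a number 2 percentage points lower from compound 2 to compound 3 (within the scatter), so on this read-out, at the one concentration tested, that group and hydrogen cannot be told apart at this position. Compounds 1 and 2 differ in two places and could not show this, whereas the new compound separates the two changes: chloro in place of fluoro on an aromatic carbon gives a number 7 percentage points lower from compound 1 to compound 3 (within the scatter), and that halogen exchange cannot be told apart on this read-out either. Nothing at hand bears on why these values lie so close together.

The compounds shown leave open whether another group on that aromatic carbon, such as a primary amine or a carboxylic acid, would shift the value in this assay beyond the scatter. They also leave open whether bromo or a nitrile in place of the chloro of the (3-chlorophenyl)carbonyl group would do so, and whether either of the two changes read here would matter at another concentration.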